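Fluoro Added to the Pyridyl Ring of Compound 3

A few compounds are considered here, and "the series" means these few. Any claim that something is new, unique, unknown or untested is made for them only; others in the source may bear on it.

Compound 3 `C[C@H]1CN(C(=O)c2ccc(-c3ccncc3)c(F)c2)CCN1C(=O)c1ccc2cc[nH]c2c1` gives 12.2 nM in a functional assay on CHO-K1 cells for antagonist activity at growth hormone secretagogue receptor type 1 (Homo sapiens), read by luminescence and calcium flux; a higher number here means a weaker inhibitor, a lower number a stronger inhibitor. Among the three measured compounds it holds the second highest number: compound 2 `Cc1ccccc1-c1ccc(C(=O)N2CCN(C(=O)c3ccc4cc[nH]c4c3)[C@@H](C)C2)cc1F` gives 9 nM, a gap within the scatter, while compound 1 `COc1cccc(-c2ccc(C(=O)N3CCN(C(=O)c4ccc5cc[nH]c5c4)C[C@@H]3C)cc2)c1` gives 280 nM, a gap beyond it. Compound 4 `C[C@H]1CN(C(=O)c2ccc(-c3ccncc3F)c(F)c2)CCN1C(=O)c1ccc2cc[nH]c2c1` differs from compound 3 by fluoro in place of hydrogen on an aromatic carbon. Going by the values given here, no measured step puts a fluoro on this ring, so there is no direct precedent. Among the compounds with values here, the only step that touches the same ring is a 1.4-fold higher number from compound 2 to compound 3 (0.13 log units; within the scatter), which exchanged a ring bearing a methyl of its own for a bare pyridin-4-yl and stayed within the scatter; a substituted ring at this position is thus tolerated in this assay. On that basis a step of no more than the scatter, in either direction, is expected. Compound 4 is therefore expected to give 12 nM in this assay, within a range from 4 nM to 40 nM, which corresponds to an expected step of a 1.0-fold lower number from compound 3 to compound 4 (0.01 log units; within the scatter).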

Compound 4, half-maximal inhibitory concentration: 42 nM
Compound 4: the middle estimate sits 3.5-fold (0.54 log units) below what was measured; measured number outside the range, above it.
By their numbers in this assay, from the lowest: compounds 2 and 3 (each within the scatter of the next); then compound 4; then compound 1.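

In this assay, fluoro in place of hydrogen on this pyridine carbon, ortho to a large group and two atoms from the ring nitrogen, gives a 3.4-fold higher number from compound 3 to compound 4 (0.54 log units; beyond the scatter), so adding this one heavy atom moves the number beyond the scatter. The earlier exchange of rings, a 1.4-fold higher number from compound 2 to compound 3 (0.13 log units; within the scatter), had stayed within the scatter and did not reveal this sensitivity, whereas 3-fluoropyridin-4-yl in place of 2-methylphenyl gives a 4.7-fold higher number from compound 2 to compound 4 (0.67 log units; beyond the scatter). The information available offers no explanation for this shift.

As far as these compounds go, what a chloro, a methyl or a methoxy on this same carbon would do remains open, so the step cannot yet be assigned to fluoro in particular rather than to any group at this carbon. Also open, from the compounds shown here alone, is how fluoro would behave on the other carbons of the pyridine ring.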